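Swapping Methyl for Phenyl on an Aryl Ether Oxygen

A few compounds are considered here, and "the series" means these few. Any claim that something is new, unique, unknown or untested is made for them only; others in the source may bear on it.

compound 1 `COc1ccc(-c2cn(-c3ccc(Oc4ccccc4)cc3)nn2)cc1`: > 100 nM
compound 2 `COc1ccc(-n2cc(-c3ccc(OC)c(O)c3)nn2)cc1`: > 10000 nM
compound 3 `COc1ccc(-n2cc(-c3ccc(OC)c(O)c3)nn2)c(OC)c1`: > 10000 nM

In a functional assay on MDA-MB-231 cells (Homo sapiens) for cytotoxicity, read by MTT assay (on this read-out lower numbers stand for stronger inhibition and higher numbers for weaker inhibition), compound 2 gives only a limit, > 10000 nM, with no number behind it. Compound 3 likewise stops at a limit, > 10000 nM. The step that the two limits leave unreadable from compound 2 to compound 3; the limit of > 10000 nM in this assay, at which 2 of the 3 values shown sit, holds two of the three values. Compound 1 stops at a different limit, > 100 nM. Compound 4 `COc1ccc(-c2cn(-c3ccc(Oc4ccccc4)cc3)nn2)cc1O` differs from compound 2 by phenyl in place of methyl on an oxygen on an aromatic ring. For the measured compounds named here, no measured step covers this change, and the values of compound 1 and compound 2 are both limits, so no size can be read from them. The expected step is a step that the limit leaves unreadable from compound 2 to compound 4, leaving compound 4 weak. Compound 4 is estimated at 15000 nM, between 3000 nM and 80000 nM, most likely reported as a limit again.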

Compound 4, half-maximal inhibitory concentration: > 10000 nM
Compound 4: a limit, no number; the forecaster's own chance of this, stated with the estimate: 70%; the middle value is on the limit's open side.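

Compound 4 gives only a limit, > 10000 nM. For the compounds shown here, compound 1 and compound 2 also stop at limits, so no step involving compound 4 can be read. On these data alone, whether phenoxy in place of methoxy changes cytotoxicity at all remains open.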